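The source may hold more compounds than are shown below. What is called first, only, known or untested is meant among the compounds shown, and "the series" means these compounds.

Among the compounds with values here, in a functional assay on CHO-K1 cells (Cricetulus griseus) for inhibition, read by MTT assay, with a stated time of 72 h (on this read-out lower numbers stand for stronger inhibition and higher numbers for weaker inhibition), compound 1 `COc1cc(/C=C/C(=O)/C=C(/C=C/c2ccc(OC(C)=O)c(OC)c2)NC2CCCCC2)ccc1OC(C)=O` gives 10100 nM, the only exact number available. Compound 2 `COc1cc(/C=C/C(=O)CC(=O)/C=C/c2ccc(OC(C)=O)c(OC)c2)ccc1OC(C)=O` reads > 25000 nM, which is a limit of the assay. Compound 3 `CCC(C)NC(=C\C(=O)/C=C/c1ccc(OC(C)=O)c(OC)c1)/C=C/c1ccc(OC(C)=O)c(OC)c1` keeps the core of compound 1 and differs on an amine nitrogen, with sec-butyl in place of cyclohexyl on an amine nitrogen. Within the data shown here, no measured step in this assay tests this exchange, so no change beyond the usual scatter is expected. The estimated move is a 1.2-fold higher number from compound 1 to compound 3 (0.07 log units; within the scatter). For compound 3, the expected value is 12000 nM, within an estimated range of 5000 nM to 25000 nM.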

Compound 3, half-maximal inhibitory concentration: > 25000 nM
Compound 3: a limit, no number (the forecaster's own chance of this, stated with the estimate: 20%); middle value at least 2.0-fold (0.31 log units) away from the limit.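

On the amine nitrogen, sec-butyl does not stand in for cyclohexyl in this assay: the exchange gives an at least 2.4-fold higher number from compound 1 to compound 3 (0.39 log units; beyond the scatter). Compound 3 reads > 25000 nM, which is a limit of the assay and not a number. How far the step really reaches cannot be told because this reading is a limit: the limit of > 25000 nM in this assay, at which 2 of the 3 values shown sit.

As far as these compounds go, it remains open whether the ring of cyclohexyl or its carbon count carries the difference. A cyclopentyl group, a phenyl group or a straight butyl chain on the same nitrogen would separate the two.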